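Butyl Gives Way to 1H-imidazol-1-yl

A few compounds are considered here, and "the series" means these few. Any claim that something is new, unique, unknown or untested is made for them only; others in the source may bear on it.

In a functional assay on C6 cells (Rattus norvegicus) for inhibition, read by sulforhodamine B assay, with a stated time of 72 h (a lower number here means that less compound is needed, a higher number that more compound is needed for the effect), compound 1 (`CSc1ccc(C(=O)/C=C/c2ccc([N+](=O)[O-])o2)cc1`) gives 1600 nM and compound 2 (`CC(C)(C)c1ccc(C(=O)/C=C/c2ccc([N+](=O)[O-])o2)cc1`) gives 28600 nM while compound 3 (`CCCCc1ccc(C(=O)/C=C/c2ccc([N+](=O)[O-])o2)cc1`) gives 1700 nM in this read-out. Compound 3 therefore sits level with compound 1 and well under compound 2. Within the data shown here, compound 4 (`O=C(/C=C/c1ccc([N+](=O)[O-])o1)c1ccc(-n2ccnc2)cc1`) carries 1H-imidazol-1-yl in place of butyl on an aromatic carbon and no measured compound carries that group. The measured steps at this carbon run from a 1.1-fold higher number from compound 1 to compound 3 (0.03 log units; within the scatter) with butyl for methylsulfanyl to an 18-fold higher number from compound 1 to compound 2 (1.25 log units; beyond the scatter) with tert-butyl for methylsulfanyl and a 17-fold lower number from compound 2 to compound 3 (1.23 log units; beyond the scatter) on returning to butyl. Only compound 2 at 28600 nM stands apart, so no step beyond the scatter is expected. The estimated step is a 1.5-fold higher number from compound 3 to compound 4 (0.17 log units; within the scatter) in this assay with wide uncertainty. Compound 4 is estimated at 2500 nM with an expected range from 700 nM to 10000 nM in this assay when measured.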

Compound 4, half-maximal effective concentration: 3500 nM
Compound 4: middle estimate off by 1.4-fold (0.15 log units), on the low side, and the stated range covers the measured number.
By their numbers in this assay, from the lowest: compounds 1 and 3 (each within the scatter of the next); then compound 4; then compound 2.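

In this assay, among these compounds, 1H-imidazol-1-yl, the only group here with a ring of its own, shows that this aromatic carbon can carry such a group at a modest cost: the data give a 2.1-fold higher number from compound 3 to compound 4 (0.31 log units; beyond the scatter) and a 2.2-fold higher number from compound 1 to compound 4 (0.34 log units; beyond the scatter) for the change. The high number of compound 2 does not return, with an 8.2-fold lower number from compound 2 to compound 4 (0.91 log units; beyond the scatter) in this series. Nothing shown explains these steps. On these data alone, whether an amine, a carboxylic acid or a longer chain would stay this close to compound 3 remains open.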